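The source may hold more compounds than are shown below. What is called first, only, known or untested is meant among the compounds shown, and "the series" means these compounds.

Of the compounds shown here, two have numbers so far. In a functional assay on SGC-7901 cells (Homo sapiens) for antiproliferative activity, read by sulforhodamine B assay, with a stated time of 72 h (a higher number here means a weaker inhibitor, a lower number a stronger inhibitor), compound 1 `COc1ccccc1NC(=S)N/N=C/c1ccc2ccccc2n1` gives only a limit, > 100000 nM, so where it stands is bounded rather than known. Compound 2 `NC(=S)N/N=C/c1cc2cccnc2s1` gives 100000 nM in this assay. Both sit at the weak end of what this assay covers; that one of the two values is the limit itself is recorded as the limit of > 100000 nM in this assay, at which 1 of the 2 values shown sits.

Compound 3 `S=C(N/N=C/c1ccc2ccccc2n1)Nc1cccc(Cl)c1` differs from compound 1 in one place: 3-chlorophenyl in place of 2-methoxyphenyl on an amide-type nitrogen. Within the data shown here, no step between measured compounds of this kind exists, so nothing measured here tells the direction of the change. The expected step of an at least 1.2-fold lower number from compound 1 to compound 3 (0.09 log units; that floor lies within the scatter) is judged as none beyond the scatter, a small gain at most. Compound 3 is therefore estimated at 80000 nM in this assay, within 20000 nM to 200000 nM, with a real chance that this assay again returns only a limit for compound 3.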

Compound 3, half-maximal inhibitory concentration: 61300 nM
For compound 3 the middle estimate is 1.3-fold (0.12 log units) above the measured one; the measured number falls inside the stated range.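

In this assay, among these compounds, compound 3 returns a number rather than a limit, so 3-chlorophenyl on this amide-type nitrogen gives the first value at this position, and the change reads as an at least 1.6-fold lower number from compound 1 to compound 3 (0.21 log units; that floor lies within the scatter). Compound 1 gives > 100000 nM, which is a limit and not a number. From the compounds shown here alone, the step is therefore only a floor, and its true size stays unknown because compound 1 stands at the limit: the limit of > 100000 nM in this assay, at which 1 of the 3 values shown sits.

The compounds shown leave open whether the gain, if real, comes from the arrival of 3-chlorophenyl or the departure of 2-methoxyphenyl. They also leave open what an unsubstituted phenyl, or a phenyl carrying an amine or a carboxylic acid, would return on this nitrogen, and whether any group here moves the series away from the weak end of this assay.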